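A few compounds are considered here, and "the series" means these few. Any claim that something is new, unique, unknown or untested is made for them only; others in the source may bear on it.

Compound 1 `COc1cc2c(cc1O)O[C@H](c1ccccc1)CC2=O`: 6700 nM
Compound 2 `COc1ccc(-c2coc3cc(O)ccc3c2=O)c(O)c1`: 34100 nM

In a functional assay on B16-BL6 cells (Mus musculus) for cytotoxicity, read by MTT assay, with a stated time of 72 h (a lower number here means a stronger inhibitor, a higher number a weaker inhibitor), compound 2 gives the highest number of the two, and compound 1 gives a clearly lower one, a gap beyond the usual scatter. Compound 3 `COc1ccc(-c2coc3cc(O)cc(O)c3c2=O)c(O)c1` is not yet measured. It differs from compound 2 by hydroxy in place of hydrogen on an aromatic carbon. For the measured compounds named here, no measured pair shows this change, so its effect here is unknown. The number for compound 3 is expected to stay close to that of compound 2, with a step of a 1.4-fold lower number from compound 2 to compound 3 (0.13 log units; within the scatter) that may well lie within the scatter. Compound 3 is estimated at 25000 nM, within a range from 8000 nM to 70000 nM.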

Compound 3, half-maximal inhibitory concentration: > 100000 nM
Compound 3 gave a limit, no number (the forecaster's own chance of this, stated with the estimate: 15%); at least 4.0-fold (0.60 log units) between middle value and limit.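

On an aromatic carbon ortho to a fused ring, hydroxy in place of hydrogen gives an at least 2.9-fold higher number from compound 2 to compound 3 (0.46 log units; beyond the scatter) in this assay. This single change therefore weakens the compound, an effect that compounds 1 and 2 alone could not reveal. For compound 3 the result is a limit of the assay, not a number, so the full size of the step remains unknown: the limit of > 100000 nM in this assay, at which 1 of the 3 values shown sits.

Going by these compounds, whether an amine or a fluorine atom on this carbon would also weaken the compound remains open. So does whether hydroxy has the same effect on the core of compound 1.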